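Fluorines in Place of Methoxy on the Ketone Aryl

The source may hold more compounds than are shown below. What is called first, only, known or untested is meant among the compounds shown, and "the series" means these compounds.

In a functional assay on A549 cells (Homo sapiens) for cytotoxicity, read by MTT assay, with a stated time of 48 h (a higher number here means a weaker inhibitor, a lower number a stronger inhibitor), compound 1 `COc1cc(-c2nnc3n2NC(c2ccco2)C(C(=O)c2ccc(F)cc2)S3)cc(OC)c1OC` gives 53700 nM. For compound 2 `COc1ccc(C(=O)C2Sc3nnc(-c4cc(OC)c(OC)c(OC)c4)n3NC2c2ccco2)cc1` this assay reports only a limit, > 100000 nM. The step of an at least 1.8-fold higher number from compound 1 to compound 2 (0.27 log units; that floor lies within the scatter) is accordingly bounded by the limit of > 100000 nM in this assay, at which 1 of the 2 values shown sits. Compound 3 `COc1cc(-c2nnc3n2NC(c2ccco2)C(C(=O)c2ccc(F)c(F)c2)S3)cc(OC)c1OC` differs from compound 2 by 3,4-difluorophenyl in place of 4-methoxyphenyl on a carbonyl carbon, which reverses the methoxy-for-fluoro exchange of the measured step and adds a second fluorine. Because an at least 1.8-fold higher number from compound 1 to compound 2 (0.27 log units; that floor lies within the scatter) ran from fluoro toward methoxy, the return to fluorine is expected to move the number back down, an at least 2.0-fold lower number from compound 2 to compound 3 (0.30 log units; that floor lies within the scatter). Compound 3 is therefore estimated at 50000 nM, within 20000 nM to 150000 nM.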

Compound 3, half-maximal inhibitory concentration: 93700 nM
The estimate for compound 3 lay 1.9-fold (0.27 log units) below the measured number, and the stated range covers the measured number.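

With 3,4-difluorophenyl in place of 4-methoxyphenyl on a carbonyl carbon, the result is an at least 1.0-fold lower number from compound 2 to compound 3 (0.02 log units; that floor lies within the scatter), so this exchange shows no separation in this assay. Fluoro in place of hydrogen on an aromatic carbon gives a 1.7-fold higher number from compound 1 to compound 3 (0.24 log units; within the scatter), so a second fluorine does not separate the two fluorinated compounds either. The step from the methoxy compound can be read only as a floor, and compound 2 stands at a limit of the assay: the limit of > 100000 nM in this assay, at which 1 of the 3 values shown sits.

From the compounds shown here alone, what remains open is whether an amine or a carboxylic acid on this aryl ring would give a number beyond the scatter in this assay.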